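Phenoxy at the benzylamine ring: expectation for compound 4

The source may hold more compounds than are shown below. What is called first, only, known or untested is meant among the compounds shown, and "the series" means these compounds.

Compound 2 `O=C(O)CCc1ccc(NCc2ccccc2)cc1` stands highest in a functional assay on CHO cells for agonist activity at Free fatty acid receptor 1 (Homo sapiens), read by reporter gene assay (a higher number here means a larger maximal response, a lower number a smaller maximal response), where compound 2 gives 144%. Compound 1 `O=C(O)CCc1ccc(NCc2ccccc2Cl)cc1` gives 122% in this assay, and compound 3 `O=C(O)CCc1ccc(NCc2cccnc2)cc1` gives 4% in this assay. The two measured steps run a number 22 percentage points higher from compound 1 to compound 2 (beyond the scatter) and a number 140 percentage points lower from compound 2 to compound 3 (beyond the scatter); both change the ring that hangs from the saturated chain carbon bound to the ring nitrogen, but neither adds a group at the position para to a large group.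

Compound 4 `O=C(O)CCc1ccc(NCc2ccc(Oc3ccccc3)cc2)cc1` differs from compound 2 by phenoxy in place of hydrogen on an aromatic carbon. Among the compounds with values here, no measured step covers a substituent entering on that ring at that place, so the measured steps bear on it only by showing that this ring tolerates change in one case and not in another. Within the data shown here, the phenoxy group is large, and with no directly comparable step the expected change is a modest drop, a number 39 percentage points lower from compound 2 to compound 4 (beyond the scatter), with wide uncertainty. Compound 4 is therefore estimated at 105%, in a range from 30% to 155%.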

Compound 4, largest response reached (reported as percent of maximum), in percent of the reference or control that the assay uses: 139%
Estimate against measurement, compound 4: 34 percentage points below; measured number inside the range.
By their numbers in this assay, from the lowest: compound 3; then compound 1; then compounds 4 and 2 (each within the scatter of the next).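

In this assay, phenoxy in place of hydrogen on an aromatic carbon, para to a large group, gives a number 5 percentage points lower from compound 2 to compound 4 (within the scatter), so this place accepts a group of 7 heavy atoms with its own six-membered aromatic ring of carbon only and the maximal response holds. The earlier steps shown here changed the ring itself or removed chloro, and the largest of them, a number 140 percentage points lower from compound 2 to compound 3 (beyond the scatter), showed how much a single change to this part of the molecule can cost; the phenoxy step shows no such cost. No measurement on hand speaks to the reason for this result.

On these data alone, whether a smaller group at this place, such as methoxy or an amine, matches phenoxy remains open. Also open, as far as these compounds go, is whether benzyloxy, with a longer link to the outer ring, or phenoxy at another place on the ring, would hold the response.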